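A few compounds are considered here, and "the series" means these few. Any claim that something is new, unique, unknown or untested is made for them only; others in the source may bear on it.

Measured so far:
- compound 1 `COCOc1cc(=O)oc2cc(OCc3cccc(Cl)c3)ccc12`, an assay on isolated protein (strain Sprague-Dawley) for inhibition of Amine oxidase [flavin-containing] B (Rattus norvegicus), read by spectrophotometry, with a stated time of 5 min; on this read-out lower numbers stand for stronger inhibition and higher numbers for weaker inhibition: 100 nM
- compound 2 `CCOC(=O)Nc1cc(=O)oc2cc(OCc3cccc(Cl)c3)ccc12`, this assay: 589 nM

For the measured compounds named here, compound 2 gives the highest of the two numbers recorded in this assay; its nearest neighbour is compound 1, and the only measured step, a 5.9-fold higher number from compound 1 to compound 2 (0.77 log units; beyond the scatter), lies beyond the scatter, so compound 2 is the weaker inhibitor of the pair.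

Compound 3 `CNc1cc(=O)oc2cc(OCc3cccc(Cl)c3)ccc12` is not yet measured. It differs from compound 2 in one place: methyl in place of ethoxycarbonyl on a nitrogen on an aromatic ring. Going by the values given here, no measured step covers this change. The step from compound 1 to compound 2 swaps a different group on a different atom and so bears on it only indirectly: it shows that the group at this position shifts the number beyond the scatter in this series, and that the compound carrying the ethoxycarbonyl is the weaker one. Removing the ethoxycarbonyl is therefore expected to move the number back toward that of compound 1, though the size of the step is uncertain.

For compound 3 the expected value is 250 nM, with a range from 60 nM to 1000 nM, meaning an expected step of a 2.4-fold lower number from compound 2 to compound 3 (0.37 log units; beyond the scatter).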

Compound 3, half-maximal inhibitory concentration: 8.71 nM
The estimate for compound 3 lay 29-fold (1.46 log units) above the measured number; the whole stated range lies above it.
By their numbers in this assay, from the lowest: compound 3; then compound 1; then compound 2.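

In this assay the change from ethoxycarbonyl to methyl on the nitrogen gives a 68-fold lower number from compound 2 to compound 3 (1.83 log units; beyond the scatter) and so shows that the group carried by this nitrogen, not just the presence of a nitrogen on the aromatic carbon, strongly sets the number. A nitrogen at this place is thus not what left compound 2 weaker than compound 1: methylamino in place of methoxymethoxy gives an 11-fold lower number from compound 1 to compound 3 (1.06 log units; beyond the scatter) in the opposite direction to a 5.9-fold higher number from compound 1 to compound 2 (0.77 log units; beyond the scatter) and makes compound 3 the strongest inhibitor of the three. Nothing measured alongside these numbers accounts for the size of either step.

The compounds shown leave open which part of the departing ethoxycarbonyl matters, as its carbonyl and its ethyl ester chain leave together, and an unsubstituted amine, an acetylamino group, an ethylamino group or a dimethylamino group would begin to separate these contributions and show how much room the nitrogen allows. Also open, from the compounds shown here alone, is whether the advantage of methylamino over methoxymethoxy persists when another part of the shared core is changed.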